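Halogen swap on the benzyl of compound 3

A few compounds are considered here, and "the series" means these few. Any claim that something is new, unique, unknown or untested is made for them only; others in the source may bear on it.

Within the data shown here, compound 3 `COc1cc(NC(=O)c2cn(Cc3ccccc3F)c3ccc(=O)[nH]c3c2=O)cc(OC)c1OC` stands highest of the three numbers so far in an in vitro assay on Sf21 cells for inhibition of high affinity 3',5'-cyclic-AMP phosphodiesterase 7A (Homo sapiens), read by scintillation proximity assay, with a stated time of 30 min (a higher number here means a weaker inhibitor, a lower number a stronger inhibitor), with compound 3 giving 206 nM. Compound 2 `O=C(Nc1ccc(OC(F)F)cc1)c1cn(Cc2c(F)cccc2F)c2ccc(=O)[nH]c2c1=O` gives 71 nM and compound 1 `CNC(=O)c1ccc(NC(=O)c2cn(Cc3c(F)cccc3F)c3ccc(=O)[nH]c3c2=O)cc1` gives 29 nM; the gaps from compound 3 to both are beyond the scatter. Among the measured compounds shown here, the one measured step, a 2.4-fold higher number from compound 1 to compound 2 (0.39 log units; beyond the scatter), concerns the amide-side aryl group, not the benzyl.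

Compound 4 `COc1cc(NC(=O)c2cn(Cc3ccccc3Br)c3ccc(=O)[nH]c3c2=O)cc(OC)c1OC` differs from compound 3 by bromo in place of fluoro on an aromatic carbon, on an aromatic carbon ortho to a large group. For the measured compounds named here, no measured step touches the benzyl halogen, so nothing bears on this change directly. In this assay the step from compound 3 to compound 4 is expected to be small, a 1.0-fold lower number from compound 3 to compound 4 (0.01 log units; within the scatter), and not clearly beyond the scatter in either direction; the estimate rests on compound 3 at 206 nM alone.

Compound 4 is estimated at 200 nM, with a range from 80 nM to 500 nM.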

Compound 4, half-maximal inhibitory concentration: > 1000 nM
Compound 4: a limit, no number; the forecaster's own chance of this, stated with the estimate: 3%; middle value at least 5.0-fold (0.69 log units) from the limit.
By their numbers in this assay, from the lowest: compound 1; then compound 2; then compound 3. At a limit, above all of these: compound 4.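

The change from 2-fluorobenzyl to 2-bromobenzyl gives an at least 4.8-fold higher number from compound 3 to compound 4 (0.68 log units; beyond the scatter) in this assay and shows that this aromatic carbon, ortho to a large group, does not accept both halogens alike, which the earlier amide-side step could not show. Compound 4 stands at a limit and not at a number, so the step has a lower bound only: the limit of > 1000 nM in this assay, at which 1 of the 4 values shown sits.

On these data alone, whether the loss also holds with the amide-side aryl groups of compound 1 and compound 2, which carry a second fluoro on the benzyl, remains open. A chloro, a methyl or a methoxy on this same carbon would show whether the step is particular to bromo.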